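Extending the Methylcarbamoyl of Compound 3 with a Pyridinyl

The source may report more compounds than this note shows. Statements on the series, on what has been measured and on what is new or still open speak of the compounds shown alone.

Three compounds have been measured in an in vitro assay on Sf21 cells for inhibition of high affinity 3',5'-cyclic-AMP phosphodiesterase 7A (Homo sapiens), read by scintillation proximity assay, with a stated time of 30 min; on this read-out higher numbers stand for weaker inhibition and lower numbers for stronger inhibition:

compound 1, `Nc1ccc(NC(=O)c2cn(Cc3c(F)cccc3F)c3ccc(=O)[nH]c3c2=O)cc1`, gives 104 nM
compound 2, `O=C(O)Cc1ccc(NC(=O)c2cn(Cc3c(F)cccc3F)c3ccc(=O)[nH]c3c2=O)cc1`, gives 176 nM
compound 3, `CNC(=O)c1ccc(NC(=O)c2cn(Cc3c(F)cccc3F)c3ccc(=O)[nH]c3c2=O)cc1`, gives 29 nM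

Compound 3 stands lowest of the three numbers. The steps leading to it are a 3.6-fold lower number from compound 1 to compound 3 (0.55 log units; beyond the scatter) and a 6.1-fold lower number from compound 2 to compound 3 (0.78 log units; beyond the scatter), while the step of a 1.7-fold higher number from compound 1 to compound 2 (0.23 log units; within the scatter) lies within the scatter. Compound 4, `O=C(NCc1ccncc1)c1ccc(NC(=O)c2cn(Cc3c(F)cccc3F)c3ccc(=O)[nH]c3c2=O)cc1`, keeps the methylcarbamoyl of compound 3 and changes it in one place: pyridin-4-yl in place of hydrogen on a saturated chain carbon bound to an amide-type nitrogen. For the measured compounds named here, none of the measured steps touches this saturated chain carbon; the two steps into compound 3 only show that the carbamoyl attachment gave the lowest number among the variations on this aromatic carbon, and they say nothing about what a further group on the methyl does. The expected step from compound 3 to compound 4 is therefore estimated as a 1.0-fold higher number from compound 3 to compound 4 (0.01 log units; within the scatter), with no direction supported beyond the scatter. Compound 4 is expected to give about 30 nM, with a range from 10 nM to 100 nM.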

Compound 4, half-maximal inhibitory concentration: 20 nM
Compound 4: the middle estimate sits 1.5-fold (0.18 log units) above what was measured, and the stated range covers the measured number.
By their numbers in this assay, from the lowest: compounds 4 and 3 (each within the scatter of the next); then compounds 1 and 2 (each within the scatter of the next).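

In this assay, the saturated chain carbon bound to an amide-type nitrogen accepts a pyridin-4-yl in place of hydrogen without a change that can be told from the scatter, with a 1.5-fold lower number from compound 3 to compound 4 (0.16 log units; within the scatter). The extended ((pyridin-4-yl)methyl)carbamoyl also keeps the separation from the other groups on the aromatic carbon, with a 5.2-fold lower number from compound 1 to compound 4 (0.72 log units; beyond the scatter) and an 8.8-fold lower number from compound 2 to compound 4 (0.94 log units; beyond the scatter), both beyond the scatter. No information is available here on why this position accepts the added ring.

The compounds shown leave open whether the ring nitrogen of the pyridin-4-yl matters, which a phenyl on the same carbon would test. They also leave open whether a longer chain between the amide-type nitrogen and the ring, or a carboxylic acid or an amine in place of the ring, would give a number beyond the scatter of compound 3.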